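A few compounds are considered here, and "the series" means these few. Any claim that something is new, unique, unknown or untested is made for them only; others in the source may bear on it.

Among the measured compounds shown here, in an ADME assay on A549 cells (Homo sapiens) for cytotoxicity, read by MTT assay (a higher number here means that more compound is tolerated, a lower number that less compound is tolerated), compound 3 `CCC#Cc1c[nH]c(=O)[nH]c1=O` gives 253000 nM and stands level, within the usual scatter, with the two other compounds measured so far. Compound 1 `C[Si](C)(C)C#Cc1c[nH]c(=O)[nH]c1=O` gives 268000 nM and compound 2 `O=c1[nH]cc(C#CC2CCCCC2)c(=O)[nH]1` gives 245000 nM on the same scale. Compound 4 `CCCCCCC#Cc1c[nH]c(=O)[nH]c1=O` lengthens the chain of compound 3 (butyl in place of hydrogen on a saturated chain carbon, two bonds along the chain from a triple-bonded carbon). For the measured compounds named here, only one measured step bears on this change, and it concerns the group on the triple-bonded carbon. Since that step is a 1.1-fold lower number from compound 1 to compound 3 (0.03 log units; within the scatter) and stays within the scatter, no step beyond the scatter is expected in this assay here. The estimate means a 1.2-fold lower number from compound 3 to compound 4 (0.06 log units; within the scatter) as the expected step. Compound 4 is expected at 220000 nM with an estimated range from 130000 nM to 330000 nM in repeated measurements.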

Compound 4, half-maximal cytotoxic concentration: 249000 nM
Beside the measured number, compound 4's estimate is 1.1-fold (0.05 log units) below it, within the range that was stated.
By their numbers in this assay, from the lowest: compounds 2, 4, 3 and 1 (each within the scatter of the next).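

In this assay butyl in place of hydrogen on a saturated chain carbon, two bonds along the chain from a triple-bonded carbon, gives a 1.0-fold lower number from compound 3 to compound 4 (0.01 log units; within the scatter) and so leaves the number level. The earlier step exchanged the whole group on the triple-bonded carbon, whereas this one extends a saturated chain, methyl to pentyl, and also stays within the scatter. No measurement shown here accounts for this flat result.

Going by these compounds, whether an amine, a carboxylic acid or a phenyl ring on the triple-bonded carbon would move the number beyond the scatter remains open.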